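This account rests on a few compounds, and the source may have more. Where it says the series, first, only, none or still open, it means among the compounds named here.

Measured so far:
compound 1 `COc1ccccc1-n1cc(COc2c(/C=C\C(=O)O)ccc(OC)c2CC=C(C)C)nn1` with 12200 nM in a functional assay on COLO 205 cells (Homo sapiens) for cytotoxicity, read by MTT assay, with a stated time of 24 h; on this read-out higher numbers stand for weaker inhibition and lower numbers for stronger inhibition;
compound 2 `COc1ccc(/C=C\C(=O)O)c(OCc2cn(-c3ccccc3I)nn2)c1CC=C(C)C` with "not determined" (no result reported).

From the compounds shown here alone, compound 2 stands on no number at all: in this assay compound 2 gives "not determined" (no result reported), so its own level is unknown, and the only measured point is compound 1. Compound 3 `COc1ccc(/C=C\C(=O)O)c(OCc2cn(-c3ccc(C#N)cc3)nn2)c1CC=C(C)C` carries 4-cyanophenyl in place of 2-iodophenyl on an aromatic nitrogen. Among the measured compounds shown here, with no measured step to lean on, the expected change from compound 2 to compound 3 cannot be sized, and none beyond the usual scatter is assumed. Compound 3 is estimated near the level of compound 1, at 11000 nM, expected between 3000 nM and 40000 nM.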

Compound 3, half-maximal inhibitory concentration: 32000 nM
Beside the measured number, compound 3's estimate is 2.9-fold (0.46 log units) below it; the range from low to high includes it.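

In this assay, 4-cyanophenyl in place of 2-methoxyphenyl on the aromatic nitrogen gives a 2.6-fold higher number from compound 1 to compound 3 (0.42 log units; beyond the scatter), the first measured sign that the aryl group at this position changes the read-out, here towards weaker inhibition. Steps involving compound 2 cannot be read, since it has no number. No available evidence accounts for this step. The compounds shown leave open whether the nitrile or its place on the ring matters more, since both differ at once. They also leave open what an amine or a carboxylic acid on this phenyl ring would do.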